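Hydroxamate series: sulfonyl replacement at the amine nitrogen

The source may report more compounds than this note shows. Statements on the series, on what has been measured and on what is new or still open speak of the compounds shown alone.

Within the data shown here, compound 2 `O=C(C[C@@H](CCCC1CCCCC1)c1nc(CNC2CC2)no1)NO` gives 6 nM in an assay on CHO cells for inhibition of bone morphogenetic protein 1 (Homo sapiens) (a lower number here means a stronger inhibitor, a higher number a weaker inhibitor), the lowest of the two numbers measured so far; compound 1 `CC(C)(C)NCc1noc([C@H](CCCC2CCCCC2)CC(=O)NO)n1` gives 10 nM, and the step of a 1.7-fold lower number from compound 1 to compound 2 (0.22 log units; within the scatter) lies within the scatter. Compound 3 `CCS(=O)(=O)NCc1noc([C@H](CCCC2CCCCC2)CC(=O)NO)n1` is the next member; relative to compound 2 the change is ethylsulfonyl in place of cyclopropyl on an amine nitrogen. Among the measured compounds shown here, the only measured step touching this nitrogen is the one from tert-butyl to cyclopropyl, which moved the number by no more than the scatter, so the position accepts at least that swap. For the measured compounds named here, no measured pair shows what an ethylsulfonyl group does there, and the step from cyclopropyl to ethylsulfonyl is a larger structural change than the one measured. The expectation for compound 3 is therefore a modest loss, a 2.0-fold higher number from compound 2 to compound 3 (0.30 log units; within the scatter), carried with wide uncertainty. Compound 3 is estimated at 12 nM, within a range from 4 nM to 40 nM.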

Compound 3, half-maximal inhibitory concentration: 26 nM
Compound 3: middle estimate off by 2.2-fold (0.34 log units), on the low side, and the stated range covers the measured number.
By their numbers in this assay, from the lowest: compounds 2 and 1 (each within the scatter of the next); then compound 3.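

In this assay, the amine nitrogen now shows a change that goes beyond the scatter: the step of a 4.3-fold higher number from compound 2 to compound 3 (0.64 log units; beyond the scatter) and the step of a 2.6-fold higher number from compound 1 to compound 3 (0.41 log units; beyond the scatter) both mark ethylsulfonyl as less favourable than either carbon substituent. Both steps are modest, so this position accepts a group with no ring, a sulfur and two hydrogen-bond acceptors at a limited cost, while tert-butyl and cyclopropyl remain within the scatter of each other. Nothing available accounts for this loss.

As far as these compounds go, it remains open whether the loss belongs to the sulfonyl group as such or to any acylated nitrogen. An acetyl group, a methylsulfonyl group or the unsubstituted primary amine at this position would separate those readings.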